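A few compounds are considered here, and "the series" means these few. Any claim that something is new, unique, unknown or untested is made for them only; others in the source may bear on it.

Measured compounds in a physicochemical assay for solubility; on this read-out lower numbers stand for lower solubility and higher numbers for higher solubility:
compound 1 (`Cn1c(C(F)(F)F)ccc(NCc2cc3cc(Cl)ccc3[nH]c2=O)c1=O`) gives < 100 nM in this assay.
compound 2 (`C[C@H](Nc1ccc(C#N)n(C)c1=O)c1cc2cc(Cl)c(O[C@H](C)c3ccccn3)cc2[nH]c1=O`) gives 1600 nM in this assay.
compound 3 (`CN1CCCC(NCc2cc3cc(Cl)ccc3[nH]c2=O)C1=O`) gives 94000 nM in this assay.

The figure for compound 1 is a limit of this assay and not a measured number, so compound 1 is known only to sit at the limit of < 100 nM in this assay, at which 1 of the 3 values shown sits. Compound 2 and compound 3 both give numbers well clear of that limit, with compound 3 the higher of the two.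

The unmeasured compound 4 (`Cn1c(C#N)ccc(NCc2cc3cc(Cl)ccc3[nH]c2=O)c1=O`) keeps the whole of compound 1 apart from one change: cyano in place of trifluoromethyl on an aromatic carbon. For the measured compounds named here, no pair of measured compounds here differs in a single place, so there is no measured step to lean on for this swap, and the starting point itself is only a limit. The expectation for compound 4 is therefore cautious: a small rise in this assay, of a size that may or may not reach beyond the usual scatter, written as an at least 1.6-fold higher number from compound 1 to compound 4 (0.20 log units; that floor lies within the scatter). On that basis compound 4 is estimated at 160 nM in this assay, with a range from 50 nM to 600 nM, and a fair chance that it too is reported only as a limit.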

Compound 4, solubility: 295 nM
The estimate for compound 4 lay 1.8-fold (0.27 log units) below the measured number, within the range that was stated.
By their numbers in this assay, from the lowest: compound 4; then compound 2; then compound 3. At a limit, below all of these: compound 1.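

In this assay, cyano in place of trifluoromethyl on this aromatic carbon, next to the ring nitrogen, gives an at least 2.9-fold higher number from compound 1 to compound 4 (0.46 log units; beyond the scatter). This is the first step shown between two compounds that differ in one place only, and it shows that the read-out responds to a change at this position by more than the usual scatter. The size of that step is only a floor, and the true step could be larger, as compound 1 stands at a limit of the assay and not at a measured number: the limit of < 100 nM in this assay, at which 1 of the 4 values shown sits.

The compounds shown leave open how other groups on this same carbon, such as a carboxylic acid, an amine or a longer chain, would compare with cyano and trifluoromethyl, and why the number moves at all, as the single step shown cannot separate one possible cause from another. They also leave open whether a step of this size would appear on a different background, for instance between compound 2, which carries cyano, and a counterpart of compound 2 bearing trifluoromethyl instead.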